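Swapping a Halogen Ring on a Chalcone Amide

This account rests on a few compounds, and the source may have more. Where it says the series, first, only, none or still open, it means among the compounds named here.

Measured so far:
compound 1 `CC(C)Cc1ccc(C(=O)/C=C/c2ccc(C(=O)O)cc2)cc1` — < 10 ug/mL
compound 2 `COC(=O)c1cc(-c2cccc(NC(=O)c3ccc(/C=C/C(=O)c4ccc(F)cc4)cc3)c2)on1` — > 20 ug/mL

Both readings are limits of the test rather than exact numbers. In an ADME assay on Vero cells (Chlorocebus sabaeus) for cytotoxicity, read by MTT assay, with a stated time of 72 h (on this read-out lower numbers stand for higher toxicity in this test and higher numbers for lower toxicity in this test), compound 1 gives < 10 ug/mL, which is the limit of < 10 ug/mL in this assay, at which 1 of the 2 values shown sits, and marks the more toxic end of what has been measured. In this assay compound 2 gives > 20 ug/mL, which is the limit of > 20 ug/mL in this assay, at which 1 of the 2 values shown sits, so compound 2 stands at the less toxic end shown, with its true value unresolved.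

Compound 3 `COC(=O)c1cc(-c2cccc(NC(=O)c3ccc(/C=C/C(=O)c4cccc(Cl)c4)cc3)c2)on1` is the next candidate. It differs from compound 2 by 3-chlorophenyl in place of 4-fluorophenyl on a carbonyl carbon. For the measured compounds named here, no measured pair shows what this change does in this assay, so the expectation is for a step of no more than the usual scatter, in either direction. The expected step is a step that the limit leaves unreadable from compound 2 to compound 3. Compound 3 is therefore expected to give about 25 ug/mL, with a range from 12 ug/mL to 60 ug/mL, most likely reported again only as a limit.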

Compound 3, half-maximal cytotoxic concentration: > 2.5 ug/mL
Compound 3 was reported as a limit; the forecaster's own chance of this, stated with the estimate: 70%; the middle value lies beyond the limit too.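

In this assay compound 3 gives > 2.5 ug/mL, which is a limit and not an exact number. Compound 2 is also known only as a limit, so no step can be read between compound 2 and compound 3. As far as these compounds go, whether 3-chlorophenyl in place of 4-fluorophenyl on a carbonyl carbon shifts the reading in this assay stays open.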